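This account rests on a few compounds, and the source may have more. Where it says the series, first, only, none or still open, it means among the compounds named here.

Measured so far in an assay for displacement of a labelled ligand from Sigma non-opioid intracellular receptor 1 (Cavia porcellus), read by scintillation counting, with a stated time of 180 min; a lower number here means a stronger inhibitor, a higher number a weaker inhibitor:
compound 1 `OC1CN(CCCCc2ccccc2)CCc2cc(OCc3ccccc3)ccc21` gives 293 nM;
compound 2 `OC1CN(CCCSc2ccccc2)CCc2cc(OCc3ccccc3)ccc21` gives 376 nM.

Compound 2 holds the highest of the two numbers, with compound 1 its nearest neighbour, but the step of a 1.3-fold higher number from compound 1 to compound 2 (0.11 log units; within the scatter) stays within the usual scatter, so the two cannot be told apart. Compound 3 `OC1CN(C2CCC3(CC2)OCCO3)CCc2cc(OCc3ccccc3)ccc21` keeps the shared core and carries the change (a group of 10 heavy atoms (8 carbon, 2 oxygen; one five-membered non-aromatic ring with 2 hetero atoms, one six-membered non-aromatic ring of carbon only) in place of a group of 10 heavy atoms (9 carbon, 1 sulfur; one six-membered aromatic ring of carbon only), on an amine nitrogen in a ring). Among the measured compounds shown here, the single measured step swapped one aromatic chain for another and barely moved the number, so it does not bear closely on an exchange that removes the aromatic ring altogether. A moderate weakening is expected, a 2.4-fold higher number from compound 2 to compound 3 (0.38 log units; beyond the scatter), so compound 3 is estimated at 900 nM, likely between 250 nM and 3500 nM.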

Compound 3, inhibition constant: 183 nM
For compound 3 the middle estimate is 4.9-fold (0.69 log units) above the measured one, outside the stated range (below it).
By their numbers in this assay, from the lowest: compounds 3, 1 and 2 (each within the scatter of the next, the first and the last beyond it).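

In this assay, a group with no aromatic ring is tolerated on the amine nitrogen in a ring: exchanging 3-(phenylsulfanyl)propyl for the two-ring group with two oxygens gives a 2.1-fold lower number from compound 2 to compound 3 (0.31 log units; beyond the scatter). Set against the chain of compound 1, the same kind of exchange gives a 1.6-fold lower number from compound 1 to compound 3 (0.20 log units; within the scatter), so those two cannot be told apart. Nothing available explains this result. As far as these compounds go, whether a plain cyclohexyl group or a ketone in place of the five-membered ring would give a similar number remains open, as does the effect of a longer chain at this nitrogen.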